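This account rests on a few compounds, and the source may have more. Where it says the series, first, only, none or still open, it means among the compounds named here.

Of the compounds shown here, three built on one shared core have been measured in an ADME assay on Caco-2 cells (Homo sapiens) for permeability, in the apical to basolateral direction; on this read-out lower numbers stand for lower permeability and higher numbers for higher permeability. Compound 1 `NC(=O)c1cccc(Oc2ccc3c(c2)c(=O)ncn3Cc2c(F)cc(F)cc2F)c1C(F)(F)F` gives 1.9 10^-6 cm/s. Compound 2 `O=c1ncn(Cc2c(F)cc(F)cc2F)c2ccc(Oc3cccc(-c4nc5ncccc5o4)c3C(F)(F)F)cc12` gives 3 10^-6 cm/s. Compound 3 `O=c1ncn(Cc2c(F)cc(F)cc2F)c2ccc(Oc3cccc(-c4ccc5[nH]ccc5c4)c3C(F)(F)F)cc12` gives 10.5 10^-6 cm/s, the highest of the three: the step of a 5.5-fold higher number from compound 1 to compound 3 (0.74 log units; beyond the scatter) and the step of a 3.5-fold higher number from compound 2 to compound 3 (0.54 log units; beyond the scatter) both lie beyond the scatter, whereas the step of a 1.6-fold higher number from compound 1 to compound 2 (0.20 log units; within the scatter) does not. Compound 4 `Cc1cc(-c2cccc(Oc3ccc4c(c3)c(=O)ncn4Cc3c(F)cc(F)cc3F)c2C(F)(F)F)cnc1N` has not yet been measured. It differs from compound 3 at the same place where the earlier changes sit: 6-amino-5-methylpyridin-3-yl in place of 1H-indol-5-yl on an aromatic carbon. The two steps ending at compound 3 bear on this, since they show that exchanging the group at this place shifts the number by modest amounts and that the indolyl group goes with the highest value seen. A change away from that group is therefore expected to bring the number down, and the step of a 3.0-fold lower number from compound 3 to compound 4 (0.48 log units; beyond the scatter) is expected to be modest and downward. Compound 4 is estimated at 3.5 10^-6 cm/s, within a range from 1.5 10^-6 cm/s to 8 10^-6 cm/s.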

Compound 4, apparent permeability: 1.1 10^-6 cm/s
The estimate for compound 4 lay 3.2-fold (0.50 log units) above the measured number, outside the stated range (below it).
By their numbers in this assay, from the lowest: compounds 4, 1 and 2 (each within the scatter of the next, the first and the last beyond it); then compound 3.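

In this assay, within the data shown here, the position on the aromatic carbon ortho to a trifluoromethyl group proves more sensitive than the earlier compounds showed: 6-amino-5-methylpyridin-3-yl in place of 1H-indol-5-yl gives a 9.5-fold lower number from compound 3 to compound 4 (0.98 log units; beyond the scatter). Carrying an aromatic ring here is also no guarantee of a high number, as a 2.7-fold lower number from compound 2 to compound 4 (0.44 log units; beyond the scatter) stays beyond the scatter while a 1.7-fold lower number from compound 1 to compound 4 (0.24 log units; within the scatter) stays within it, so only compound 3 goes against the low cluster. Nothing available explains this drop.

The compounds shown leave open which part of the exchange matters, since the ring system, the ring nitrogen, the amino group and the methyl group all change at once. A plain phenyl group or a 6-aminopyridin-3-yl group without the methyl at this position would help separate these parts.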